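This account rests on a few compounds, and the source may have more. Where it says the series, first, only, none or still open, it means among the compounds named here.

Of the compounds shown here, three with a shared core have been tested in an ADME assay (liver) for metabolic stability, with Liver microsome (Homo sapiens) as the target, read by LC-MS, using microsomes and NADPH, with a stated time of 5 min, at 37 degrees C; on this read-out lower numbers stand for slow clearance and higher numbers for fast clearance. Compound 1 `CCn1c([C@@H](C)NS(=O)(=O)c2ccc(Cl)cc2)nc2cccc(Cl)c21` gives > 100 mL.min-1.g-1, which is a limit of the assay and not a number. Compound 2 `CCn1c([C@@H](C)NS(=O)(=O)c2cccc(C#N)c2)nc2ccc(C(F)(F)F)cc21` gives > 100 mL.min-1.g-1, which is also a limit. Compound 3 `CCn1c([C@@H](C)NS(=O)(=O)c2ccc(NC(C)=O)c(C)c2)nc2ccc(C(F)(F)F)cc21` gives > 100 mL.min-1.g-1, again a limit. The whole record so far is the limit of > 100 mL.min-1.g-1 in this assay, at which 3 of the 3 values shown sit. Compound 2 therefore has no exact value, and the three compounds cannot be ranked against one another.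

Compound 4 `CCn1ncc(S(=O)(=O)N[C@H](C)c2nc3ccc(C(F)(F)F)cc3n2CC)c1C` differs from compound 2 in a single group: 1-ethyl-5-methyl-1H-pyrazol-4-yl in place of 3-cyanophenyl on a sulfonyl sulfur. Here 1-ethyl-5-methyl-1H-pyrazol-4-yl stands in place of 3-cyanophenyl on a sulfonyl sulfur. Among the measured compounds shown here, no measured pair shows what a swap of this kind does, so any forecast is loose. For the measured compounds named here, the only anchor is compound 2 with > 100 mL.min-1.g-1, a limit. A modest move towards slower clearance seems the fair expectation, and it may not exceed the usual scatter, so a result at the same limit would be no surprise. The expected change is an at least 1.4-fold lower number from compound 2 to compound 4 (0.15 log units; that floor lies within the scatter). For compound 4 the estimated intrinsic clearance is 70 mL.min-1.g-1, with an expected range from 30 mL.min-1.g-1 to 150 mL.min-1.g-1.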

Compound 4, intrinsic clearance in microsomes: > 100 mL.min-1.g-1
Compound 4 was reported as a limit; the forecaster's own chance of this, stated with the estimate: 45%; middle value at least 1.4-fold (0.15 log units) away from the limit.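

Compound 2 and compound 4 both come out as limits and not numbers, so the swap from 3-cyanophenyl to 1-ethyl-5-methyl-1H-pyrazol-4-yl cannot be read as a step. All four compounds share one result: the limit of > 100 mL.min-1.g-1 in this assay, at which 4 of the 4 values shown sit. Still open, on these data alone, is how the four compounds rank, and which change, if any, would give a readable number.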